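Working notes: methoxy step towards compound 3

The compounds below may be only part of what the source reports. "The series", "measured", "known", "first", "only" and "open" are said of these compounds alone.

- compound 1 `COc1cccc(-c2cc(=O)c3cc(N)ccc3o2)c1` gives 247000 nM
- compound 2 `Nc1ccc2oc(-c3ccccc3)c(O)c(=O)c2c1` gives 217000 nM

In an ADME assay on MT4 cells (Homo sapiens) for cytotoxicity, read by MTT assay, with a stated time of 4 days (on this read-out higher numbers stand for lower toxicity in this test and lower numbers for higher toxicity in this test), compound 2 lies within the usual scatter of compound 1, so the two values show no order. Compound 3 `COc1cccc(-c2oc3ccc(N)cc3c(=O)c2O)c1` is compound 2 with methoxy in place of hydrogen on an aromatic carbon, meta to a large group. Among the measured compounds shown here, no measured pair isolates this change. The expected 1.1-fold lower number from compound 2 to compound 3 (0.04 log units; within the scatter) stays within the scatter, with no direction favoured, and this rests only on compound 1 at 247000 nM and compound 2 at 217000 nM lying so close. Compound 3 is estimated at 200000 nM, with the expected range running from 100000 nM to 400000 nM in this assay.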

Compound 3, half-maximal cytotoxic concentration: 40800 nM
Compound 3: the middle estimate sits 4.9-fold (0.69 log units) above what was measured; the measured number lies below the stated range.
By their numbers in this assay, from the lowest: compound 3; then compounds 2 and 1 (each within the scatter of the next).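

In this assay the methoxy in place of hydrogen on an aromatic carbon, meta to a large group, gives a 5.3-fold lower number from compound 2 to compound 3 (0.73 log units; beyond the scatter) and so is a change this position registers. The added hydroxy gives a 6.1-fold lower number from compound 1 to compound 3 (0.78 log units; beyond the scatter) on the same read-out. Compound 3 carries both groups and stands apart from compound 1 and compound 2, and nothing at hand gives a reason for this.

Going by these compounds, a compound with neither group remains open, so the separate part of each cannot be read. On these data alone, whether ethoxy or a carboxylic acid on that aromatic carbon would follow methoxy also remains open.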